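Swapping a Halogen on a Shared Core

The source may report more compounds than this note shows. Statements on the series, on what has been measured and on what is new or still open speak of the compounds shown alone.

Two measured compounds set the scene. Compound 1 `COc1ccc(-c2cc(-c3ccc(F)cc3)nc(NC(=O)N/N=C\c3ccc([N+](=O)[O-])cc3)n2)cc1OC` was tested in a functional assay on the whole organism (strain Albino) with Mus musculus as the target, with a stated time of 0.5 h (on this read-out lower numbers stand for an effect already at smaller amounts and higher numbers for an effect only at larger amounts of compound), and gave 300 mg/kg. Compound 2 `COc1ccc(-c2cc(-c3ccc(F)cc3)nc(NC(=O)N/N=C(/C)c3ccc(Cl)cc3)n2)cc1` was measured in the same this assay and gave 300 mg/kg. On these numbers compound 1 stands level with compound 2; the two values agree at the digits shown and lie within the scatter of each other, so no order between them can be read. Compound 3 `COc1ccc(-c2cc(-c3ccc(Cl)cc3)nc(NC(=O)N/N=C\c3ccc([N+](=O)[O-])cc3)n2)cc1OC` has not yet been measured in this assay. It differs from compound 1 by chloro in place of fluoro on an aromatic carbon, the halogen being exchanged on the aromatic carbon para to a large group. Going by the values given here, no step between measured compounds is available to calibrate such a swap. Among the compounds with values here, with only two values, both the same, to go on, the step in this assay is expected to be none beyond the scatter, no change at the digits printed from compound 1 to compound 3 (within the scatter). Compound 3 is therefore estimated at 300 mg/kg, with a range from 150 mg/kg to 600 mg/kg.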

Compound 3, dose for half-maximal effect: 100 mg/kg
Estimate against measurement, compound 3: 3.0-fold (0.48 log units) above, and the stated range ends above it.
By their numbers in this assay, from the lowest: compound 3; then compounds 1 and 2 (each within the scatter of the next).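

The exchange of 4-fluorophenyl to 4-chlorophenyl is not silent in this assay: chloro in place of fluoro gives a 3.0-fold lower number from compound 1 to compound 3 (0.48 log units; beyond the scatter), a modest step but one beyond the scatter. This shows that the number responds to the identity of the halogen on this aromatic carbon, para to a large group, which the level values of the two earlier compounds could not reveal, as no step could be read between them. Nothing measured here bears on why the number falls with this exchange.

Going by these compounds, this rests on a single pair, so it remains open whether the same exchange would give a similar step alongside the different side chain of compound 2. Also open, on these data alone, is how bromo, trifluoromethyl or an amine would read at this position.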